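The source may hold more compounds than are shown below. What is called first, only, known or untested is meant among the compounds shown, and "the series" means these compounds.

Measured in a functional assay, with a stated time of 30 min; on this read-out lower numbers stand for stronger inhibition and higher numbers for weaker inhibition:

- compound 1 `COC(=O)c1c(C(=O)c2c(O)cc(C)cc2OC)c(OC)cc(O)c1[S@+](C)[O-]`: > 100000 nM (a limit of the assay)
- compound 2 `COc1c(O)c(O)c(C)c2scnc12`: 3450 nM

Going by the values given here, only two compounds have been tested so far, and they share little in structure. Compound 1 reaches only a limit of this assay, at > 100000 nM. Among the compounds with values here, that leaves compound 2 with the only true number, at 3450 nM, so it is the single reference point for what follows.

The next compound to be tested is compound 3 `COc1c(O)c(O)c(C)c2sc(CO)nc12`. It keeps the core of compound 2 and makes one change, (hydroxymethyl in place of hydrogen on an aromatic carbon). In words, this is hydroxymethyl in place of hydrogen on an aromatic carbon, next to the ring nitrogen and next to the ring sulfur.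

Within the data shown here, no step between measured compounds shows what such a change does in this assay. The expectation therefore starts from compound 2 at 3450 nM, with no direction favoured and no shift expected beyond the usual scatter. The expected step is a 1.0-fold higher number from compound 2 to compound 3 (0.01 log units; within the scatter). The estimated value for compound 3 is 3500 nM, with an expected range from 1200 nM to 11000 nM.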

Compound 3, half-maximal inhibitory concentration: 23700 nM
The estimate for compound 3 lay 6.8-fold (0.83 log units) below the measured number; measured number above the stated range.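

In this assay, going by these compounds alone, the aromatic carbon next to the ring nitrogen and next to the ring sulfur proves sensitive to substitution, something the earlier compounds could not show: hydroxymethyl in place of hydrogen gives a 6.9-fold higher number from compound 2 to compound 3 (0.84 log units; beyond the scatter). Since a higher number stands for weaker inhibition here, this single change costs inhibition by more than the usual scatter, although the size of the step is modest and compound 3 still gives a measurable number of 23700 nM. The step is read between two true numbers, and the only limit among the compounds shown belongs to compound 1: the limit of > 100000 nM in this assay, at which 1 of the 3 values shown sits.

This one step cannot say whether the weaker inhibition goes with the added carbon, with the oxygen of the hydroxymethyl group or with any substituent at all at this position, and it gives no reason for the change. A plain methyl group would help separate those readings, while an amine, a carboxylic acid or a longer chain in the same place would show whether the trend seen with compound 3 holds beyond this single group.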